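Replacing a pyrimidine with isoquinoline in a weak series

This account rests on a few compounds, and the source may have more. Where it says the series, first, only, none or still open, it means among the compounds named here.

Compound 2, with the structure `CC(C)[C@H](NC(=O)COc1cccc2ccccc12)C(=O)N[C@@H](CC(=O)O)C(=O)COc1nccc(C(F)(F)F)n1`, carries a (4-(trifluoromethyl)pyrimidin-2-yl)oxy group on a saturated chain carbon bound to a carbonyl carbon. In a functional assay on Jurkat cells (Homo sapiens) for inhibition (a lower number here means a stronger inhibitor, a higher number a weaker inhibitor), compound 2 gives only a limit, > 200000 nM. Its neighbour compound 1, `CC(C)[C@H](NC(=O)COc1cccc2ccccc12)C(=O)N[C@@H](CC(=O)O)C(=O)CSc1nccn1C`, bears (1-methyl-1H-imidazol-2-yl)sulfanyl at that place. In this assay compound 1 likewise gives only a limit, > 200000 nM. The step from one to the other is therefore a step that the two limits leave unreadable from compound 1 to compound 2, and the evidence so far is the limit of > 200000 nM in this assay, at which 2 of the 2 values shown sit. Compound 3, `CC(C)[C@H](NC(=O)COc1cccc2ccccc12)C(=O)N[C@@H](CC(=O)O)C(=O)COc1cncc2ccccc12`, differs from compound 2 by isoquinolin-4-yl in place of 4-(trifluoromethyl)pyrimidin-2-yl on an oxygen on a saturated carbon. No measured step bears on that change, so no direction can be read from the numbers shown, and a limit is again the most likely outcome. The expected step is a number no higher from compound 2 to compound 3 (the limit leaves the size open), and compound 3 is estimated at 200000 nM, within 40000 nM to 1000000 nM.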

Compound 3, half-maximal inhibitory concentration: 166000 nM
Estimate against measurement, compound 3: 1.2-fold (0.08 log units) above; the measured number falls inside the stated range.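

With (isoquinolin-4-yl)oxy at this place, compound 3 gives a measured number rather than a limit in this assay: 166000 nM. Against the pyrimidine, the change gives an at least 1.2-fold lower number from compound 2 to compound 3 (0.08 log units; that floor lies within the scatter), and against the sulfanyl group it gives an at least 1.2-fold lower number from compound 1 to compound 3 (0.08 log units; that floor lies within the scatter); each is only a floor, so neither shows a real gain on its own. For the compounds shown here, the one readable number therefore marks where measurement begins in this small set, while the other values remain limits: the limit of > 200000 nM in this assay, at which 2 of the 3 values shown sit.

As far as these compounds go, the true size of both steps stays open, as does whether the isoquinolin-4-yl group or the oxygen link matters more in the comparison with compound 1. From the compounds shown here alone, it is also open whether an amine or a methoxy group added to the isoquinolin-4-yl group would lower the number in this assay.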